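Chromene series: carboxamide replaced by ethoxymethyl

The source may hold more compounds than are shown below. What is called first, only, known or untested is meant among the compounds shown, and "the series" means these compounds.

Measured so far:
compound 1, `COc1ccc2c(c1)OC(c1cc(OC)c(OC)c(OC)c1)C(C(=O)NC(C)(C)C)=C2`, 28400 nM
compound 2, `COc1ccc2c(c1)OC(c1cc(OC)c(OC)c(OC)c1)C(C(=O)N(C)OC)=C2`, 11700 nM

In a functional assay for inhibition of nuclear factor NF-kappa-B complex (Homo sapiens) (on this read-out lower numbers stand for stronger inhibition and higher numbers for weaker inhibition), compound 2 holds the lowest number of the two, with compound 1 giving 28400 nM, the step being a 2.4-fold lower number from compound 1 to compound 2 (0.39 log units; beyond the scatter). Compound 3, `CCOCC1=Cc2ccc(OC)cc2OC1c1cc(OC)c(OC)c(OC)c1`, differs from compound 2 by ethoxymethyl in place of methoxy(methyl)carbamoyl on a double-bonded ring carbon. Among the measured compounds shown here, the only measured step changes the substituent on the amide nitrogen, so it bears only loosely on removing the carbonyl altogether. For the measured compounds named here, no step shows what loss of the carbonyl does. The expectation for compound 3 is therefore a number close to compound 2, the step being a 1.3-fold higher number from compound 2 to compound 3 (0.11 log units; within the scatter), within the scatter. Compound 3 is estimated at 15000 nM, between 5000 nM and 45000 nM.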

Compound 3, half-maximal inhibitory concentration: 21300 nM
For compound 3 the middle estimate is 1.4-fold (0.15 log units) below the measured one, and the stated range covers the measured number.
By their numbers in this assay, from the lowest: compounds 2, 3 and 1 (each within the scatter of the next, the first and the last beyond it).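

In this assay, the carbonyl and the amide nitrogen can both go from this double-bonded ring carbon without a clear shift: ethoxymethyl gives a 1.8-fold higher number from compound 2 to compound 3 (0.26 log units; within the scatter), and a 1.3-fold lower number from compound 1 to compound 3 (0.12 log units; within the scatter). Compound 3 thus sits within the scatter of both amides, although those two differ from each other beyond it. Nothing available accounts for this result.

Open, as far as these compounds go, is whether a basic amine such as aminomethyl, a carboxylic acid or a longer ether chain at this carbon would move the number beyond the scatter of compound 3.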